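Compound 3: One Methoxy Added, No Baseline to Compare

The compounds below may be only part of what the source reports. "The series", "measured", "known", "first", "only" and "open" are said of these compounds alone.

Compound 1 `COc1cc(/C=C\c2csc3ccccc23)cc(OC)c1OC`: 288 nM
Compound 2 `COc1cc(/C=C\c2cccs2)cc(OC)c1OC`: "not determined" (no result reported)

In a functional assay on IC8 cells (Homo sapiens) for antiproliferative activity, read by MTT assay, with a stated time of 72 h (a lower number here means a stronger inhibitor, a higher number a weaker inhibitor), compound 2 has no number. For the measured compounds named here, its entry reads "not determined" (no result reported), so it cannot be placed relative to compound 1, and no step can be measured from it.

Compound 3 `COc1csc(/C=C\c2cc(OC)c(OC)c(OC)c2)c1` differs from compound 2 at one place, thiophen-2-yl to 4-methoxythiophen-2-yl: methoxy in place of hydrogen on an aromatic carbon. The methoxy replaces hydrogen on an aromatic carbon of the five-membered aromatic ring with 1 sulfur, two ring bonds from the ring sulfur and two ring bonds from the ring atom that bears a large group.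

Going by the values given here, no measured pair shows what this change does in this assay, so any expectation is loose. A modest step toward stronger inhibition from compound 2 is expected, though its size cannot be tested without a baseline. Among the compounds with values here, the only available anchor is compound 1 at 288 nM, and compound 3 is expected to fall in that broad region, probably on the weaker side. For compound 3 the estimated value is 500 nM, with an expected range of 90 nM to 2800 nM.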

Compound 3, half-maximal inhibitory concentration: 27 nM
Compound 3: the middle estimate sits 19-fold (1.27 log units) above what was measured; the whole stated range lies above it.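

No step can be read between compound 2 and compound 3: in this assay compound 2 has no number to set beside compound 3 at 27 nM. The compounds shown leave open what methoxy in place of hydrogen on this ring does to inhibition. Nothing shown accounts for the value of compound 3.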